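Hydroxy in place of methoxy on a pyrazole urea

This account rests on a few compounds, and the source may have more. Where it says the series, first, only, none or still open, it means among the compounds named here.

For the measured compounds named here, compound 2 `COc1cc(-c2nn(-c3cccc(NC(=O)Nc4ccc(Cl)c(C(F)(F)F)c4)c3)cc2-c2ccncc2)ccc1Cl` is the one compound of this pair with a number: in a functional assay on HCC 2998 cells (Homo sapiens) for inhibition, read by sulforhodamine B assay, with a stated time of 48 h (on this read-out lower numbers stand for stronger inhibition of growth and higher numbers for weaker inhibition of growth), compound 2 gives 7300 nM. Compound 1 `O=C(Nc1cccc(-n2cc(-c3ccncc3)c(-c3ccc(Cl)c(O)c3)n2)c1)Nc1cccc(C(F)(F)F)c1` gives only a limit in this assay, > 32500 nM, as stated in the limit of > 32500 nM in this assay, at which 1 of the 2 values shown sits. Compound 3 `O=C(Nc1cccc(-n2cc(-c3ccncc3)c(-c3ccc(Cl)c(O)c3)n2)c1)Nc1ccc(Cl)c(C(F)(F)F)c1` has not yet been measured in this assay. It differs from compound 2 by hydrogen in place of methyl on an oxygen on an aromatic ring. Going by the values given here, no measured step covers this change, so the expectation rests on what the two values show: compound 2, carrying the methoxy group, gives a number, while the hydroxy-bearing compound 1 reaches only the limit. A step toward weaker growth inhibition, beyond the usual scatter, is expected from compound 2 to compound 3, a 2.7-fold higher number from compound 2 to compound 3 (0.44 log units; beyond the scatter). Compound 3 is therefore estimated at 20000 nM, within a range from 6000 nM to 60000 nM, with a real chance of only a limit being reported.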

Compound 3, concentration for total growth inhibition: 4120 nM
For compound 3 the middle estimate is 4.9-fold (0.69 log units) above the measured one; measured number below the stated range.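

In this assay, hydroxy in place of methoxy on the 4-chloro-3-methoxyphenyl group gives a 1.8-fold lower number from compound 2 to compound 3 (0.25 log units; within the scatter), so on this evidence the methyl on this oxygen can be replaced by hydrogen without a change the assay can resolve. The clear difference lies at another place: chloro in place of hydrogen on an aromatic carbon gives an at least 7.8-fold lower number from compound 1 to compound 3 (0.89 log units; beyond the scatter), which shows that the hydroxy group does not by itself confine a compound of this series to a limit. That step has only a lower bound, since compound 1 is reported as a limit: the limit of > 32500 nM in this assay, at which 1 of the 3 values shown sits.

As far as these compounds go, it remains open whether a larger group on this oxygen, such as an ethyl ether or an acetate ester, would keep growth inhibition at this level. From the compounds shown here alone, it also remains open whether an amine in place of the hydroxy would do so.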